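The source may report more compounds than this note shows. Statements on the series, on what has been measured and on what is new or still open speak of the compounds shown alone.

Compound 1, `Nc1ccc(S(=O)(=O)N2CCN(c3ncc(C(O)(C(F)(F)F)C(F)(F)F)cc3C#CCCO)CC2)cn1`, and compound 2, `CS(=O)(=O)Nc1cccc(-c2cc(C(O)(C(F)(F)F)C(F)(F)F)cnc2N2CCN(S(=O)(=O)c3ccc(N)nc3)CC2)c1`, share one core and differ only where the 4-hydroxybut-1-yn-1-yl group of compound 1 is exchanged for 3-(methanesulfonamido)phenyl. In an ADME assay (liver) for metabolic stability, with Liver microsome (Homo sapiens) as the target, using microsomes and NADPH, with a stated time of 30 min, tested at 1 uM (a lower number here means slower removal, a higher number faster removal of the compound), compound 1 gives only a limit of the assay, < 14 mL.min-1.g-1. In this assay, among the compounds with values here, compound 2 gives 40 mL.min-1.g-1, the only number among the two values shown. The other value shown is that of compound 1, which sits at the limit of < 14 mL.min-1.g-1 in this assay, at which 1 of the 2 values shown sits. The step of an at least 2.8-fold higher number from compound 1 to compound 2 (0.45 log units; beyond the scatter) is beyond the scatter. Compound 3, `Nc1ccc(S(=O)(=O)N2CCN(c3ncc(C(O)(C(F)(F)F)C(F)(F)F)cc3-c3ccc4sccc4c3)CC2)cn1`, carries the change (1-benzothiophen-5-yl in place of 3-(methanesulfonamido)phenyl on an aromatic carbon). Within the data shown here, no measured step touches this pair directly; the single step from compound 1 to compound 2 only shows that an aryl group at this position can be cleared faster than the alkyne, so nothing beyond a modest shift is expected. Compound 3 is estimated at 60 mL.min-1.g-1, between 25 mL.min-1.g-1 and 150 mL.min-1.g-1, which is a step of a 1.5-fold higher number from compound 2 to compound 3 (0.18 log units; within the scatter) that is expected to stay near the scatter.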

Compound 3, intrinsic clearance in microsomes: 48 mL.min-1.g-1
Compound 3: the middle estimate sits 1.3-fold (0.10 log units) above what was measured, within the range that was stated.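

In this assay, 1-benzothiophen-5-yl in place of 3-(methanesulfonamido)phenyl gives a 1.2-fold higher number from compound 2 to compound 3 (0.08 log units; within the scatter), so these two aryl groups are not told apart at this position, although one carries a hydrogen-bond donor and the other none. The gap from the alkyne now appears with a second aryl group, as 1-benzothiophen-5-yl in place of 4-hydroxybut-1-yn-1-yl gives an at least 3.4-fold higher number from compound 1 to compound 3 (0.53 log units; beyond the scatter). Compound 1 is represented in this comparison only by a limit of the assay: the limit of < 14 mL.min-1.g-1 in this assay, at which 1 of the 3 values shown sits.

Within the data shown here, compounds 2 and 3 are the only aryl examples set against the single alkyne of compound 1, so it remains open whether the gap holds for aryl groups in general. Also open, from the compounds shown here alone, is how a simple phenyl, a carboxylic acid on the aryl ring or a saturated amine such as piperidine at this position would behave in this assay.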